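Replacing Hydroxy with Methylamino in Compound 2

The source may report more compounds than this note shows. Statements on the series, on what has been measured and on what is new or still open speak of the compounds shown alone.

Compound 2 `C=CCn1ccc(N2C[C@H](CO)OC2=O)c1` is the weaker of the two measured compounds in an assay for inhibition of Amine oxidase [flavin-containing] B (Bos taurus), read by fluorescence, with a stated time of 30 min (a higher number here means a weaker inhibitor, a lower number a stronger inhibitor), where compound 2 gives 625000 nM. Among the measured compounds shown here, its only measured neighbour, compound 1 `CCn1ccc(N2C[C@H](CO)OC2=O)c1`, differs in the chain on the aromatic nitrogen and gives 300 nM; the step between them is a 2100-fold higher number from compound 1 to compound 2 (3.32 log units; beyond the scatter). Compound 3 `C=CCn1ccc(N2C[C@H](CNC)OC2=O)c1` is not yet measured and differs from compound 2 by methylamino in place of hydroxy on a saturated chain carbon bound to a saturated ring carbon. For the measured compounds named here, no measured step touches this part of the molecule: the single step available concerns the chain on the aromatic nitrogen, which compound 2 and compound 3 share. With nothing to go on there, the expected step of no change at the digits printed from compound 2 to compound 3 (within the scatter) is no larger than the usual scatter, in no clear direction. Compound 3 is therefore estimated at 625000 nM, with a wide range from 120000 nM to 3000000 nM, since a value this weak may also come back only as a limit of this assay.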

Compound 3, inhibition constant: 2000 nM
Estimate against measurement, compound 3: 310-fold (2.49 log units) above, and the stated range ends above it.
By their numbers in this assay, from the lowest: compound 1; then compound 3; then compound 2.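

Replacing hydroxy with methylamino on a saturated chain carbon bound to a saturated ring carbon gives a 310-fold lower number from compound 2 to compound 3 (2.49 log units; beyond the scatter) in this assay. Among the compounds shown here, this shows that the position, which no earlier step touched, can shift the number far beyond the scatter, just as the chain on the aromatic nitrogen did. The two groups have the same hydrogen-bond donor and acceptor counts and no net charge, so those counts do not distinguish them, and nothing available explains the size of this step.

Going by these compounds, it remains open whether the step follows the nitrogen or its added methyl, which a primary amine or a dimethylamino group at the same place could help separate. On these data alone, the effect of methylamino with the chain on the aromatic nitrogen of compound 1 also remains open.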